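The source may report more compounds than this note shows. Statements on the series, on what has been measured and on what is new or still open speak of the compounds shown alone.

Compound 2 `C#Cc1cn([C@@H]2O[C@H](CO)[C@@H](O)[C@H]2O)c2nc(N)nc(OC)c12` stands at the edge of what a functional assay on HCT-116 cells (Homo sapiens), read by MTT assay, with a stated time of 72 h (a lower number here means a stronger inhibitor, a higher number a weaker inhibitor), can report: its value of > 20000 nM is a limit of the measurement, not a number. Compound 1 `Cc1nc(N)c2c(-c3ccco3)cn([C@@H]3O[C@H](CO)[C@@H](O)[C@H]3O)c2n1` also gives a limit, > 20000 nM in this assay. Only compound 3 `C#Cc1cn([C@@H]2O[C@H](CO)[C@@H](O)[C@H]2O)c2ncnc(OC)c12` yields a number, 5140 nM in this assay. Within the data shown here, the single measured step, an at least 3.8-fold lower number from compound 2 to compound 3 (0.59 log units; beyond the scatter), can be stated only as a bound because of the limit of > 20000 nM in this assay, at which 2 of the 3 values shown sit.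

Compound 4 `COc1nc(N)nc2c1c(-c1cc3ccccc3o1)cn2[C@@H]1O[C@H](CO)[C@@H](O)[C@H]1O` arises from compound 2 by 1-benzofuran-2-yl in place of ethynyl on an aromatic carbon. Among the measured compounds shown here, no measured step speaks to this change: the one step known, from compound 2 to compound 3, concerns the amino on an aromatic carbon, which compound 4 keeps, and compound 1, which also bears a ring group in place of ethynyl together with the amino, gives only a limit. So nothing in the numbers points to a gain or a loss in this assay from 1-benzofuran-2-yl in place of ethynyl, and compound 4 is expected to remain near where compound 2 stands, most likely again at a limit. Compound 4 is therefore estimated at 20000 nM in this assay, within 5000 nM to 80000 nM, a step of a number no higher from compound 2 to compound 4 (the limit leaves the size open) that is expected to lie within the scatter.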

Compound 4, half-maximal inhibitory concentration: > 20000 nM
Compound 4: no number, only a limit; the forecaster's own chance of this, stated with the estimate: 60%; the middle value lies on the limit itself.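

In this assay compound 4 gives > 20000 nM, which is a limit and not a number. Compound 2 also stands at a limit, so no step from it to compound 4 can be read: the limit of > 20000 nM in this assay, at which 3 of the 4 values shown sit.

The compounds shown leave open whether 1-benzofuran-2-yl in place of ethynyl changes the number in this assay at all.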